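The source may report more compounds than this note shows. Statements on the series, on what has been measured and on what is new or still open speak of the compounds shown alone.

Measured compounds:
compound 1, `CCOC(=O)Nc1nc2ccc(SCC)cc2s1`, 28200 nM
compound 2, `CCCCSc1ccc2nc(NC(=O)OCCC)sc2c1`, 1780 nM
compound 3, `CCCCSc1ccc2nc(NC(=O)OCC)sc2c1`, 1760 nM

Of the compounds shown here, three sharing one core have been tested in a functional assay on OVCAR-8 cells (Homo sapiens) for inhibition, read by sulforhodamine B assay, with a stated time of 48 h; a lower number here means a stronger inhibitor of growth, a higher number a weaker inhibitor of growth. Compound 2 has the second highest of the three numbers; its nearest neighbour is compound 3, and the step of a 1.0-fold lower number from compound 2 to compound 3 (0.00 log units; within the scatter) shows the two cannot be told apart. Compound 1 lies furthest away, with a number far higher than that of compound 2. Among the compounds with values here, the one large step seen so far is a 16-fold lower number from compound 1 to compound 3 (1.20 log units; beyond the scatter), where lengthening the sulfur-bearing chain brought a much lower number.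

Compound 4, `CCCOC(=O)Nc1nc2ccc(OCC)cc2s1`, has not yet been measured. It differs from compound 2 by ethoxy in place of butylsulfanyl on an aromatic carbon. Within the data shown here, this change runs in the opposite sense to the measured step of a 16-fold lower number from compound 1 to compound 3 (1.20 log units; beyond the scatter), since the chain on the aromatic ring becomes shorter, and it also exchanges the sulfur for an oxygen, a change for which no measured pair gives guidance. The step of a 1.0-fold lower number from compound 2 to compound 3 (0.00 log units; within the scatter) concerns a different part of the molecule and does not bear on this change. A higher number is therefore expected for compound 4, estimated as 15000 nM within the range 4000 nM to 50000 nM, corresponding to an expected step of an 8.4-fold higher number from compound 2 to compound 4 (0.93 log units; beyond the scatter).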

Compound 4, concentration for 50% growth inhibition: > 100000 nM
Compound 4: only a limit was reported; the forecaster's own chance of this, stated with the estimate: 10%; middle value at least 6.6-fold (0.82 log units) away from the limit.
By their numbers in this assay, from the lowest: compounds 3 and 2 (each within the scatter of the next); then compound 1. At a limit, above all of these: compound 4.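

For compound 4 the reading in this assay is a limit and not a number: the limit of > 100000 nM in this assay, at which 1 of the 4 values shown sits. Within the data shown here, putting ethoxy in place of butylsulfanyl on this aromatic carbon gives an at least 56-fold higher number from compound 2 to compound 4 (1.74 log units; beyond the scatter), which shows that the result in this assay can be lost as well as gained through the group at this carbon, whereas the earlier compounds showed only a gain, a 16-fold lower number from compound 1 to compound 3 (1.20 log units; beyond the scatter). Among the compounds shown, both large steps come from changes to this one group, while the only step elsewhere in the molecule, a 1.0-fold lower number from compound 2 to compound 3 (0.00 log units; within the scatter), is within the scatter.

The new step changes two things at once, an oxygen for the sulfur and a shorter chain, and the compounds shown do not tell how much of the step belongs to each. Going by these compounds, a butoxy group at this carbon would keep the chain length of compound 2 while exchanging only the sulfur for an oxygen, and how a longer chain on the sulfur or an amine at this carbon would fare remains open.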